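The compounds below may be only part of what the source reports. "The series", "measured", "known", "first", "only" and "open" are said of these compounds alone.

Measured compounds:
compound 1, `CCCSc1nc(N)c2nc(O)n(Cc3ccccc3)c2n1`: 0.01 uM
compound 2, `CSc1nc2c(N)ncnc2n1Cc1ccccc1`: > 10 uM
compound 3, `COc1ccc(Cn2c(O)nc3c(N)ncnc32)cc1`: 10 uM

Of the compounds shown here, three sharing one core have been tested in a functional assay (spleen, spleen) for activation, with Mus musculus as the target; a higher number here means that more compound is needed for the effect, a lower number that less compound is needed. Compound 1 gives the lowest of the two numbers shown, 0.01 uM. The nearest number belongs to compound 3, which needs far more compound, 10 uM, a gap well beyond the scatter of repeated measurements. For compound 2 this assay reports only a limit, > 10 uM, as noted in the limit of > 10 uM in this assay, at which 1 of the 3 values shown sits; no number is known for it.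

The next compound, compound 4, `CCCCCSc1nc(N)c2nc(O)n(Cc3ccccc3)c2n1`, has not yet been measured in this assay. It differs from compound 1 in one place: ethyl in place of hydrogen on a saturated chain carbon, three bonds along the chain from a sulfur. Read one bond further out, the propyl of compound 1 becomes a pentyl in compound 4. Among the compounds with values here, no measured pair in this set shows what lengthening this chain does, so the expectation rests on compound 1 alone. The step from compound 1 to compound 4 is expected to be a 1.2-fold higher number from compound 1 to compound 4 (0.08 log units; within the scatter), within or near the scatter. Compound 4 is therefore expected to give about 0.012 uM, between 0.003 uM and 0.05 uM.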

Compound 4, minimum effective concentration: 10 uM
Compound 4: the middle estimate sits 830-fold (2.92 log units) below what was measured, and the stated range ends below it.
By their numbers in this assay, from the lowest: compound 1; then compounds 3 and 4 (each within the scatter of the next).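

Within the data shown here, this pair is the first in the set to change only the chain on sulfur, and it shows that this position is far from indifferent in this assay: lengthening propyl to pentyl gives a 1000-fold higher number from compound 1 to compound 4 (3.00 log units; beyond the scatter). The low number of compound 1 therefore depends strongly on this chain, and adding just an ethyl at its far end is enough to lose it. Nothing shown here explains why the longer chain needs so much more compound.

The compounds shown leave open whether the number climbs gradually or abruptly with chain length, which a butyl chain would help to settle. They also leave open whether an ethyl chain, or a propyl chain ending in an amine or a hydroxyl group, would keep the low number of compound 1.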